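The source may hold more compounds than are shown below. What is called first, only, known or untested is meant among the compounds shown, and "the series" means these compounds.

Measured in a physicochemical assay for solubility, read by chemiluminescence, measured as kinetic solubility; on this read-out lower numbers stand for lower solubility and higher numbers for higher solubility:
- compound 1 `Cn1ncc2c(NS(=O)(=O)c3cccc(Cl)c3Cl)cccc21`: 170000 nM
- compound 2 `COc1nn(C(C)C)c2ncnc(NS(=O)(=O)c3cccc(Cl)c3Cl)c12`: 404000 nM

Compound 1 stands at 170000 nM. Compound 2 holds the higher of the two numbers, and its gap to compound 1 lies beyond the scatter. Compound 3 `COc1nn(C2COC2)c2ncnc(NS(=O)(=O)c3cccc(Cl)c3Cl)c12` is unmeasured and carries oxetan-3-yl in place of isopropyl on an aromatic nitrogen. Among the measured compounds shown here, no measured pair covers this change, so the expectation is tentative. In this assay a small upward step, not beyond the scatter, is expected. The expected step is a 1.3-fold higher number from compound 2 to compound 3 (0.11 log units; within the scatter). The estimate for compound 3 is 520000 nM, with an expected range of 280000 nM to 950000 nM.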

Compound 3, solubility: 142000 nM
Estimate against measurement, compound 3: 3.7-fold (0.56 log units) above; the measured number lies below the stated range.
By their numbers in this assay, from the lowest: compounds 3 and 1 (each within the scatter of the next); then compound 2.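

On the aromatic nitrogen, the group matters in this assay, where oxetan-3-yl in place of isopropyl gives a 2.8-fold lower number from compound 2 to compound 3 (0.45 log units; beyond the scatter) in the shared core. Among the compounds shown here, this is the first single-place step, and it runs downward with a four-membered ring and a hydrogen-bond acceptor entering. No measurement at hand explains this step.

This single pair leaves open whether the step holds on other cores. Cyclobutyl or azetidin-3-yl on that nitrogen would show whether the step goes with the ring or with the oxygen.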